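The source may hold more compounds than are shown below. What is called first, only, known or untested is meant among the compounds shown, and "the series" means these compounds.

Measured so far in a functional assay on cells (Panel NCI-60 (60 carcinoma cell lines), Homo sapiens) for inhibition, read by colorimetric assay, with a stated time of 3 days; on this read-out lower numbers stand for stronger inhibition of growth and higher numbers for weaker inhibition of growth:
- compound 1 `O=C(CCCCCCNC(=O)C(O)(O)C(F)(F)F)Nc1ncc(-c2ccc(Br)cc2)s1` (11400 nM)
- compound 2 `COc1ccc2sc(NC(=O)CCCCCCNC(=O)C(O)(O)C(F)(F)F)nc2c1` (12300 nM)

Only these two compounds have been measured, and compound 2 (12300 nM) stands level with compound 1 (11400 nM), within the scatter of each other. Compound 3 `O=C(CCCCCCNC(=O)C(O)(O)C(F)(F)F)Nc1nc2ccccc2s1` follows from compound 2 by a single change, hydrogen in place of methoxy on an aromatic carbon, on a six-membered aromatic ring of carbon only. For the measured compounds named here, no measured pair shows this change alone. Yet compound 1 (11400 nM) and compound 2 (12300 nM) differ by far more than this and still show no gap beyond the scatter, so only a small effect is expected. The expected step (a 1.1-fold higher number from compound 2 to compound 3 (0.06 log units; within the scatter)) lies within the scatter. For compound 3 the estimated value is 14000 nM (expected range 7000 nM to 30000 nM).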

Compound 3, concentration for total growth inhibition: 21400 nM
For compound 3 the middle estimate is 1.5-fold (0.18 log units) below the measured one; the measured number falls inside the stated range.
By their numbers in this assay, from the lowest: compounds 1, 2 and 3 (each within the scatter of the next).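

In this assay, for the compounds shown here, hydrogen in place of methoxy on an aromatic carbon of the six-membered aromatic ring of carbon only gives a 1.7-fold higher number from compound 2 to compound 3 (0.24 log units; within the scatter) and is the first step to isolate this single change. At this position, then, losing the methoxy group, with its 2 heavy atoms and 1 hydrogen-bond acceptor, leaves no difference beyond the scatter on this read-out. No independent measurement bears on the reason for this result.

The compounds shown leave open whether a group such as an amine or a carboxylic acid at this same aromatic carbon would also stay within the scatter. They also leave open how the read-out responds to a change elsewhere in the molecule, such as a longer chain.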